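Chloro to Fluoro at the Same Aromatic Carbon

The source may report more compounds than this note shows. Statements on the series, on what has been measured and on what is new or still open speak of the compounds shown alone.

Compound 1, `c1ccc(-c2n[nH]cc2N2CCNCC2)cc1`, gives 185 nM in an assay on isolated protein for binding affinity to 5-hydroxytryptamine receptor 6 (Homo sapiens); on this read-out higher numbers stand for weaker inhibition and lower numbers for stronger inhibition. Compound 2, `Clc1ccc(-c2n[nH]cc2N2CCNCC2)cc1`, gives 75 nM in this assay.

Among the compounds with values here, compound 2 holds the lower of the two numbers measured so far; the only step on record, a 2.5-fold lower number from compound 1 to compound 2 (0.39 log units; beyond the scatter), is modest and beyond the scatter. Compound 3, `Fc1ccc(-c2n[nH]cc2N2CCNCC2)cc1`, has not yet been measured. It differs from compound 2 by fluoro in place of chloro on an aromatic carbon. Within the data shown here, the one measured step that bears on this, a 2.5-fold lower number from compound 1 to compound 2 (0.39 log units; beyond the scatter), shows what chloro at this carbon adds relative to hydrogen. Fluoro at the same carbon is neither hydrogen nor chloro, so the expected number for compound 3 is estimated to sit between those of compound 1 and compound 2, with the step of a 1.6-fold higher number from compound 2 to compound 3 (0.20 log units; within the scatter) likely small and possibly within the scatter. Compound 3 is therefore expected to give about 120 nM, plausibly between 60 nM and 240 nM.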

Compound 3, inhibition constant: 373 nM
For compound 3 the middle estimate is 3.1-fold (0.49 log units) below the measured one; measured number above the stated range.
By their numbers in this assay, from the lowest: compound 2; then compounds 1 and 3 (each within the scatter of the next).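

The choice of halogen at this aromatic carbon clearly counts in this assay, since the change from chloro to fluoro gives a 5.0-fold higher number from compound 2 to compound 3 (0.70 log units; beyond the scatter) and so sets the two halogens apart. Fluoro, on the other hand, cannot be told apart from hydrogen here, with a 2.0-fold higher number from compound 1 to compound 3 (0.30 log units; within the scatter) in the comparison of those two compounds, so the lower number seen so far belongs to chloro and not to halogens in general. Nothing on record explains why the two halogens behave differently here.

The compounds shown leave open whether a larger halogen such as bromo, or a group such as methyl or methoxy, at this carbon would track with chloro or with fluoro. They also do not show whether chloro would keep its lower number on another carbon of the same ring.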